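Methoxy to hydroxyl on the triazole-linked phenyl ring

The source may report more compounds than this note shows. Statements on the series, on what has been measured and on what is new or still open speak of the compounds shown alone.

Measured so far:
Compound 1 `O=C1O/C(=C\Cn2cc(-c3ccc(Br)cc3)nn2)C(OCc2ccccc2)=C1OCc1ccccc1` — in a functional assay on MCF7 cells (Homo sapiens) for antiproliferative activity, read by MTT assay, with a stated time of 72 h (a higher number here means a weaker inhibitor, a lower number a stronger inhibitor), a limit, > 100000 nM
Compound 2 `COc1ccc(-c2cn(C/C=C3\OC(=O)C(OCc4ccccc4)=C3OCc3ccccc3)nn2)cc1` — in this assay 39100 nM

Among the compounds with values here, compound 2 gives the only numerical value here, 39100 nM in this assay. For compound 1 this assay reports only a limit, > 100000 nM, and no number. Within the data shown here, the one measured step, an at least 2.5-fold lower number from compound 1 to compound 2 (0.40 log units; beyond the scatter), is therefore a lower bound rather than a settled size, and it rests on (the limit of > 100000 nM in this assay, at which 1 of the 2 values shown sits).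

Compound 3 `O=C1O/C(=C\Cn2cc(-c3cccc(O)c3)nn2)C(OCc2ccccc2)=C1OCc1ccccc1` differs from compound 2 in one place: 3-hydroxyphenyl in place of 4-methoxyphenyl on an aromatic carbon. Among the measured compounds shown here, this change sits on the same phenyl ring that the measured step altered, so that step is the only comparison that bears on it; it shows that a change on this ring can move the result by at least a modest amount, but gives no direction for a hydroxyl in place of a methoxy, nor for the shift of position around the ring. With no closer guide, the expectation is a step of about a 1.2-fold higher number from compound 2 to compound 3 (0.06 log units; within the scatter), within the scatter. Compound 3 is thus estimated at 45000 nM, with a likely range from 15000 nM to 130000 nM.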

Compound 3, half-maximal inhibitory concentration: 27800 nM
Compound 3: the middle estimate sits 1.6-fold (0.21 log units) above what was measured, and the stated range covers the measured number.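

In this assay, the phenyl ring on this position tolerates a real change of group without a clear shift in the result: 4-methoxyphenyl gives way to 3-hydroxyphenyl, which brings a hydrogen-bond donor where the group it replaces has none, and the outcome is a 1.4-fold lower number from compound 2 to compound 3 (0.15 log units; within the scatter). The comparison with the bromo compound now has a second partner, and an at least 3.5-fold lower number from compound 1 to compound 3 (0.55 log units; beyond the scatter) is, like the earlier step, beyond the scatter. That size remains a lower bound and not a settled figure because compound 1 is reported only as a limit: the limit of > 100000 nM in this assay, at which 1 of the 3 values shown sits.

Two things changed at once in the step to compound 3, the group on the ring and its position around the ring, so the compounds shown cannot separate one from the other; 4-hydroxyphenyl and 3-methoxyphenyl would be the two partners that pull them apart. As far as these compounds go, it also remains open how an amine or a carboxylic acid on this phenyl ring would behave, and whether any group here can bring the number far lower.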